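Shortening the Chain on Nitrogen: Compound 2 to Compound 4

This account rests on a few compounds, and the source may have more. Where it says the series, first, only, none or still open, it means among the compounds named here.

Three compounds built on one shared core differ only in the halogen on the aromatic ring: compound 1 `CC(C)n1c(/C=C2/C(=O)Nc3ccc(F)cc32)nc2ccccc21`, compound 2 `CC(C)n1c(/C=C2/C(=O)Nc3ccc(Cl)cc32)nc2ccccc21` and compound 3 `CC(C)n1c(/C=C2/C(=O)Nc3ccc(Br)cc32)nc2ccccc21`. In a functional assay on BT-549 cells (Homo sapiens) for cytotoxicity, read by MTT assay, with a stated time of 48 h (on this read-out higher numbers stand for weaker inhibition and lower numbers for stronger inhibition), compound 1 gives 26700 nM, compound 2 gives 35100 nM and compound 3 gives 13700 nM. Compound 2 carries the highest number of the three: the step of a 1.3-fold higher number from compound 1 to compound 2 (0.12 log units; within the scatter) is within the scatter, whereas a 2.6-fold lower number from compound 2 to compound 3 (0.41 log units; beyond the scatter) is beyond it.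

Compound 4 `CCn1c(/C=C2/C(=O)Nc3ccc(Cl)cc32)nc2ccccc21` changes a different part of the molecule: hydrogen in place of methyl on a saturated chain carbon bound to an aromatic nitrogen and a saturated chain carbon, isopropyl to ethyl. Going by the values given here, no measured step touches this chain, since every one of them swaps a halogen instead. With nothing to guide a direction, the expected step is a 1.0-fold lower number from compound 2 to compound 4 (0.00 log units; within the scatter), none beyond the scatter. Compound 4 is therefore estimated to give 35000 nM, with a range from 12000 nM to 100000 nM.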

Compound 4, half-maximal inhibitory concentration: > 50000 nM
Compound 4: a limit, no number; the forecaster's own chance of this, stated with the estimate: 10%; middle value at least 1.4-fold (0.15 log units) from the limit.
By their numbers in this assay, from the lowest: compounds 3, 1 and 2 (each within the scatter of the next, the first and the last beyond it). At a limit, above all of these: compound 4.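

Compound 4 gives > 50000 nM in this assay, which is a limit and not a number. Going by these compounds alone, this is the first information about the chain rather than the halogen: going from isopropyl to ethyl gives an at least 1.4-fold higher number from compound 2 to compound 4 (0.15 log units; that floor lies within the scatter), so shortening this chain brought no lower number, though the true size of the step remains unknown. That floor is shared by few values here: the limit of > 50000 nM in this assay, at which 1 of the 4 values shown sits.

On these data alone, what a longer chain, such as butyl, or a chain ending in an amine would give stays open. So does whether the same shortening behaves alike with fluoro or bromo on the aromatic ring.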